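The compounds below may be only part of what the source reports. "The series", "measured", "known", "first", "only" and "open" are said of these compounds alone.

Compound 1 `CCCn1c(=O)n(C2CCC(COC(C)=O)O2)c2nc(NC(C)=O)nc(O)c21`: 80 uM
Compound 2 `CN(C)CCCn1c(=O)n(C2OC(CO)[C@@H](O)[C@H]2O)c2nc(N)nc(O)c21`: 820 uM

Of the compounds shown here, two have been measured in a functional assay with Mus musculus as the target; on this read-out lower numbers stand for an effect already at smaller amounts and higher numbers for an effect only at larger amounts of compound. Compound 1 `CCCn1c(=O)n(C2CCC(COC(C)=O)O2)c2nc(NC(C)=O)nc(O)c21` gives 80 uM in this assay. Going by the values given here, compound 2 `CN(C)CCCn1c(=O)n(C2OC(CO)[C@@H](O)[C@H]2O)c2nc(N)nc(O)c21` gives 820 uM in this assay, the higher of the two numbers, and the gap to compound 1 is wider than the usual scatter; no step between these two is defined, so their values stand side by side without a counted structural difference.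

The piece follows the step from compound 2 to compound 3 `NC(=O)Cn1c(=O)n(C2OC(CO)[C@@H](O)[C@H]2O)c2nc(N)nc(O)c21`, which is not yet measured. The change is carbamoyl in place of 2-(dimethylamino)ethyl on a saturated chain carbon bound to an aromatic nitrogen. Among the compounds with values here, no measured pair shows what this kind of change does here, so the step is expected to be small, with no clear direction beyond the scatter: compound 3 is estimated to stand at a 1.4-fold lower number from compound 2 to compound 3 (0.14 log units; within the scatter) from compound 2. In this assay compound 3 is therefore expected near 600 uM, with a range from 150 uM to 2500 uM.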

Compound 3, concentration for half-maximal effect: 117 uM
The estimate for compound 3 lay 5.1-fold (0.71 log units) above the measured number, and the stated range ends above it.
By their numbers in this assay, from the lowest: compounds 1 and 3 (each within the scatter of the next); then compound 2.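

In this assay, the group on a saturated chain carbon bound to an aromatic nitrogen turns out to matter: carbamoyl in place of 2-(dimethylamino)ethyl gives a 7.0-fold lower number from compound 2 to compound 3 (0.85 log units; beyond the scatter), with the rest of the molecule unchanged. Going by these compounds alone, this is the first single change that can be read at this position, and it shows that giving up the dimethylamino-bearing chain does not cost activity on this read-out. The step exchanges several features at once, including the chain, the amine and the carbonyl, and nothing available here accounts for its size.

Going by these compounds, it remains open whether the gain follows from removing the amine, from shortening the chain or from adding the carbamoyl. A longer chain ending in carbamoyl, a carboxylic acid or a short chain ending in a hydroxyl group could help to separate these.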